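The source may report more compounds than this note shows. Statements on the series, on what has been measured and on what is new or still open speak of the compounds shown alone.

Three compounds have been measured in a functional assay on Ehrlich cells (Mus musculus) for cytotoxicity, read by trypan blue exclusion, with a stated time of 2 h, tested at 100 ug/mL; a lower number here means a weaker effect, a higher number a stronger effect of the compound at the concentration tested:

compound 1, `N#CC1=C(N)N(c2ccc(S(N)(=O)=O)cc2)C2=C(C(=O)CCC2)C1c1ccc(Cl)cc1Cl`, gives 95%
compound 2, `N#CC1=C(NC(=O)/C=C/c2ccccc2)N(c2ccc(S(N)(=O)=O)cc2)C2=C(C(=O)CCC2)C1c1ccc(Cl)cc1Cl`, gives 45%
compound 3, `CN(C)c1ccc(/C=N/C2=C(C#N)C(c3ccc(Cl)cc3Cl)C3=C(CCCC3=O)N2c2ccc(S(N)(=O)=O)cc2)cc1`, gives 40%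

Compound 1 stands highest of the three. Its nearest neighbour is compound 2, reached by a number 50 percentage points lower from compound 1 to compound 2 (beyond the scatter), and its furthest is compound 3, reached by a number 55 percentage points lower from compound 1 to compound 3 (beyond the scatter). Compound 4, `CC(=O)CC(=O)NC1=C(C#N)C(c2ccc(Cl)cc2Cl)C2=C(CCCC2=O)N1c1ccc(S(N)(=O)=O)cc1`, is not yet measured. It differs from compound 1 in one place: (2-oxopropyl)carbonyl in place of hydrogen on an amine nitrogen, that is, amino becomes ((2-oxopropyl)carbonyl)amino. For the measured compounds named here, two measured steps bear on this. The step from compound 1 to compound 2 also puts a carbonyl-bearing group in place of hydrogen on the same amine nitrogen, and it is large and downward. The step from compound 1 to compound 3 changes the same position in another way and is likewise large and downward. Compound 4 is therefore expected to show a large downward step, a number 50 percentage points lower from compound 1 to compound 4 (beyond the scatter), in this assay. The value for compound 4 is estimated at 45%, within a range from 25% to 70%.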

Compound 4, a percentage reported as activity, at one concentration (the size of the read-out at that concentration, not a potency): 80%
The estimate for compound 4 lay 35 percentage points below the measured number; the measured number lies above the stated range.
By their numbers in this assay, from the lowest: compounds 3 and 2 (each within the scatter of the next); then compound 4; then compound 1.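

In this assay, a carbonyl-bearing group on the amine nitrogen need not cost most of the effect: (2-oxopropyl)carbonyl in place of hydrogen gives a number 15 percentage points lower from compound 1 to compound 4 (beyond the scatter), whereas the earlier changes at this position gave only large steps. The group on the carbonyl carbon matters, as 2-oxopropyl in place of 2-phenylethenyl gives a number 35 percentage points higher from compound 2 to compound 4 (beyond the scatter). The group of compound 4, which has no ring, also differs clearly from the ring-bearing group of compound 3, giving a number 40 percentage points higher from compound 3 to compound 4 (beyond the scatter).

Nothing shown here accounts for these steps. As far as these compounds go, it remains open whether the ring in the entering group sets the lower level, and how a plain acetyl group or a longer chain ending in a carboxylic acid would behave on the same nitrogen.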